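Notes on the series: from compound 2 to compound 3

A few compounds are considered here, and "the series" means these few. Any claim that something is new, unique, unknown or untested is made for them only; others in the source may bear on it.

Compound 1 `O=C(O)CCCCCCCC#CC#CC#CC#C[C@@H](O)CO`: 11.9 ug/mL
Compound 2 `C[C@H](O)C#CC#CC#CC#CCCCCCCCC(=O)O`: 2.8 ug/mL

In a functional assay on KB cells (Homo sapiens) for cytotoxicity, in the presence of a further agent that is not named here (on this read-out higher numbers stand for an effect only at larger amounts of compound and lower numbers for an effect already at smaller amounts), compound 1 gives 11.9 ug/mL and compound 2 gives 2.8 ug/mL. Compound 2 holds the lowest of the two numbers; its nearest neighbour is compound 1, reached through the step of a 4.3-fold lower number from compound 1 to compound 2 (0.63 log units; beyond the scatter).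

Compound 3 `C[C@H](O)/C=C/C#CC#CC#CCCCCCCCC(=O)O` carries 3-hydroxybut-1-en-1-yl in place of 3-hydroxybut-1-yn-1-yl on a triple-bonded carbon. For the measured compounds named here, that one measured step concerns the hydroxy only and does not bear on this change; no measured pair speaks to it, so no step beyond the scatter is expected, with a 1.3-fold higher number from compound 2 to compound 3 (0.10 log units; within the scatter) as the estimated step. Compound 3 is expected to give 3.5 ug/mL, within 1.2 ug/mL to 10 ug/mL.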

Compound 3, concentration for half-maximal effect: > 20 ug/mL
Compound 3: no number, only a limit; the forecaster's own chance of this, stated with the estimate: 5%; middle value at least 5.7-fold (0.75 log units) from the limit.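

In this assay compound 3 gives > 20 ug/mL, a limit of the assay and not a number: the limit of > 20 ug/mL in this assay, at which 1 of the 3 values shown sits. Unlike the hydroxy step, this change at a triple-bonded carbon, 3-hydroxybut-1-en-1-yl in place of 3-hydroxybut-1-yn-1-yl, shows that the position responds to the bond in the side chain, with an at least 7.1-fold higher number from compound 2 to compound 3 (0.85 log units; beyond the scatter). The replacement of 3,4-dihydroxybut-1-yn-1-yl gives an at least 1.6-fold higher number from compound 1 to compound 3 (0.22 log units; that floor lies within the scatter), so that floor alone does not separate the two compounds.

From the compounds shown here alone, the full size of both steps remains open while compound 3 stands as a limit. Also open, going by these compounds, is how an amine in place of the hydroxy would read on this side chain.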